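A few compounds are considered here, and "the series" means these few. Any claim that something is new, unique, unknown or untested is made for them only; others in the source may bear on it.

Among the measured compounds shown here, compound 1 `COc1ccccc1N1CCN(CCCCCn2c(=O)[nH]c3ccccc32)CC1` is one of two compounds measured in an assay on HEK293 cells for displacement of a labelled ligand from 5-hydroxytryptamine receptor 7 (Homo sapiens) (a higher number here means a weaker inhibitor, a lower number a stronger inhibitor), and in this assay compound 1 gives 38 nM. The other measured compound, compound 2 `O=c1n(CCN2CCN(c3ccccc3)CC2)c2ccccc2n1-c1ccccc1`, gives 1230 nM in this assay, so compound 1 stands at the lower of the two numbers, and the gap between them is beyond the scatter. Compound 2 differs from compound 1 in more than one place, so the two values only show where each lands. Compound 3 `O=c1[nH]c2ccccc2n1CCCCCN1CCN(c2ccccc2)CC1` is not yet measured. It differs from compound 1 in a single place: hydrogen in place of methoxy on an aromatic carbon. For the measured compounds named here, no measured pair shows this change by itself, so its size is open. I expect the step from compound 1 to compound 3 to be modest and toward a higher number, a 2.9-fold higher number from compound 1 to compound 3 (0.46 log units; beyond the scatter), possibly within the scatter. For compound 3 the estimated value is 110 nM, with a range from 35 nM to 350 nM.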

Compound 3, inhibition constant: 6 nM
For compound 3 the middle estimate is 18-fold (1.26 log units) above the measured one; measured number below the stated range.
By their numbers in this assay, from the lowest: compound 3; then compound 1; then compound 2.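

In this assay, replacing methoxy with hydrogen on this aromatic carbon, ortho to a large group, gives a 6.3-fold lower number from compound 1 to compound 3 (0.80 log units; beyond the scatter), a step beyond the scatter. Compound 3 thus binds more strongly without the methoxy, so in this pair the group is not needed for binding at this receptor and the plain phenyl does better than the 2-methoxyphenyl. Nothing available here explains why the number falls.

From the compounds shown here alone, this is a single pair, so it remains open whether a fluorine, a chlorine, a methyl or an ethoxy at the same place would give a value closer to that of compound 3 or that of compound 1. Going by these compounds, it is also open whether the same swap would move the number in the same direction on a shorter or longer chain.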